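Three Polyene Esters at the Assay Limit, and a Thiazole

The source may hold more compounds than are shown below. What is called first, only, known or untested is meant among the compounds shown, and "the series" means these compounds.

Compound 1 `CCOC(=O)/C=C/C=C/C=C/c1ccc[nH]1`: > 10000 nM
Compound 2 `CCOC(=O)/C=C/C=C/C=C/C=C/C=C/c1ccc[nH]1`: > 10000 nM
Compound 3 `CCOC(=O)/C=C/C=C/C=C/C=C/c1cccn1C`: > 10000 nM

In a functional assay on Raji cells (Homo sapiens) for cytotoxicity, with a stated time of 72 h (on this read-out lower numbers stand for stronger inhibition and higher numbers for weaker inhibition), compound 1 gives > 10000 nM, which is a limit of the assay and not a number. Compound 2 gives > 10000 nM, again a limit. Compound 3 gives > 10000 nM, also a limit. The whole set therefore sits in one place: the limit of > 10000 nM in this assay, at which 3 of the 3 values shown sit. With no true number among the three, the results give no ranking, and compound 1 stands level with the others at that limit.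

Among the measured compounds shown here, the next compound to be tested, compound 4 `CCOC(=O)/C=C/C=C/C=C/c1nccs1`, keeps the core of compound 1 and changes only one group: 1,3-thiazol-2-yl in place of 1H-pyrrol-2-yl on a double-bonded chain carbon bound to a double-bonded chain carbon. Here 1,3-thiazol-2-yl takes the place of 1H-pyrrol-2-yl on a double-bonded chain carbon bound to a double-bonded chain carbon. For the measured compounds named here, no measured pair shows the size of such a swap on its own, so the expectation has to rest on the starting point. Compound 1 reads > 10000 nM, a limit. The expected change is none beyond the usual scatter, in either direction: a number no higher from compound 1 to compound 4 (the limit leaves the size open). Another limit is the most likely result. Compound 4 is estimated at 10000 nM, with an expected range of 4000 nM to 30000 nM.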

Compound 4, half-maximal inhibitory concentration: 4350 nM
Estimate against measurement, compound 4: 2.3-fold (0.36 log units) above, and the stated range covers the measured number.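

Among the compounds shown here, putting 1,3-thiazol-2-yl in place of 1H-pyrrol-2-yl on a double-bonded chain carbon bound to a double-bonded chain carbon gives an at least 2.2-fold lower number from compound 1 to compound 4 (0.36 log units; beyond the scatter), the first step in the set that can be read at all, and it lies beyond the usual scatter. So the group at this place can shift the result in this assay, although the effect is modest and the size stated is only a floor, since the starting point, compound 1, is a limit and not a number. Compound 4 is also the only compound here with a true value, while the others offer no number to compare against: the limit of > 10000 nM in this assay, at which 3 of the 4 values shown sit.

The swap changes several things at once, including the ring's hetero atoms and the loss of the hydrogen-bond donor of 1H-pyrrol-2-yl, so this single pair cannot tell which of them matters. Also open, going by these compounds, is whether a plain phenyl ring or a 1,3-oxazol-2-yl group at the same place would do as well, and whether 1,3-thiazol-2-yl would behave the same on a longer chain or with a carboxylic acid in place of the ethyl ester.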